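Adding a Diethylaminoethyl Chain to a Small Core

A few compounds are considered here, and "the series" means these few. Any claim that something is new, unique, unknown or untested is made for them only; others in the source may bear on it.

Of the compounds shown here, three sharing one core have been measured in a physicochemical assay for solubility, in the presence of a further agent that is not named here; on this read-out lower numbers stand for lower solubility and higher numbers for higher solubility. Compound 1 `Cc1ccc2c(c1)[n+]([O-])c(N)n[n+]2[O-]` carries a bare amino group on that core, and in this assay compound 1 gives 3000000 nM. Compound 2 `CC1CCCC(C)N1CCNc1n[n+]([O-])c2ccccc2[n+]1[O-]` gives 48000000 nM, and compound 3 `CCCN(CCC)CCNc1n[n+]([O-])c2ccc(Cl)cc2[n+]1[O-]` gives 600000 nM. Compound 1 therefore stands second highest of the three: it lies below compound 2 and above compound 3, and both of those gaps are beyond the usual scatter of repeat measurements.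

Compound 4 `CCN(CC)CCNc1n[n+]([O-])c2ccc(C)cc2[n+]1[O-]` has not yet been measured. It differs from compound 1 in one place: 2-(diethylamino)ethyl in place of hydrogen on a nitrogen on an aromatic ring. Among the measured compounds shown here, no directly comparable pair of measured compounds differs in exactly this way, so the size of the step is uncertain. Compound 2 and compound 3, which both carry a chain of this general kind, sit on either side of compound 1, so only a modest upward step from compound 1 to compound 4 is expected, a 2.0-fold higher number from compound 1 to compound 4 (0.30 log units; within the scatter), and it may fall within the scatter. Compound 4 is estimated at 6000000 nM, with a likely range from 1200000 nM to 30000000 nM.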

Compound 4, solubility: > 49000000 nM
Compound 4 ended at the assay's limit; the forecaster's own chance of this, stated with the estimate: 5%; at least 8.1-fold (0.91 log units) between middle value and limit.
By their numbers in this assay, from the lowest: compound 3; then compound 1; then compound 2. At a limit, above all of these: compound 4.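

In this assay, among the compounds shown here, 2-(diethylamino)ethyl in place of hydrogen on a nitrogen on an aromatic ring gives an at least 16-fold higher number from compound 1 to compound 4 (1.21 log units; beyond the scatter), a large step and the first one measured between compounds that differ in one place. Compound 4 gives > 49000000 nM, which is a limit of the assay and not a number. The step therefore sets only a floor on the size of this change, and how far compound 4 truly lies from compound 1 stays unknown: the limit of > 49000000 nM in this assay, at which 1 of the 4 values shown sits.

On these data alone, whether a plain hexyl chain, made of carbon only, would give a step of like size in the same place stays open. Also open, as far as these compounds go, is how a 2-morpholinoethyl group or a chain ending in a carboxylic acid would compare there.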